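The source may hold more compounds than are shown below. What is called first, only, known or untested is meant among the compounds shown, and "the series" means these compounds.

Measured so far:
compound 1 `CCCCC(C)NCC(N)=O`: 640 mg/kg
compound 2 `NC(=O)[C@@H](CO)NCc1ccc(OCc2ccccc2)cc1`: 133 mg/kg

Within the data shown here, in a functional assay on the whole organism with Mus musculus as the target (a lower number here means that less compound is needed, a higher number that more compound is needed for the effect), compound 2 gives 133 mg/kg, the lowest of the two numbers known so far; compound 1 gives 640 mg/kg, a gap that lies beyond the usual scatter. Compound 3 `CNC(=O)[C@@H](NCc1ccc(OCc2ccccc2)cc1)C(C)C` has not yet been measured. It differs from compound 2 in a single place: 2-methyl-1-(methylcarbamoyl)propyl in place of 1-carbamoyl-2-hydroxyethyl on an amine nitrogen. Among the measured compounds shown here, no measured pair shows what such a change does, so the direction of the step is open. The step of a 1.1-fold higher number from compound 2 to compound 3 (0.05 log units; within the scatter) is expected to stay within the scatter. For compound 3 the estimate is 150 mg/kg, between 60 mg/kg and 400 mg/kg.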

Compound 3, dose for half-maximal effect: 55.4 mg/kg
Beside the measured number, compound 3's estimate is 2.7-fold (0.43 log units) above it; the measured number lies below the stated range.
By their numbers in this assay, from the lowest: compound 3; then compound 2; then compound 1.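

On an amine nitrogen, 2-methyl-1-(methylcarbamoyl)propyl in place of 1-carbamoyl-2-hydroxyethyl gives a 2.4-fold lower number from compound 2 to compound 3 (0.38 log units; beyond the scatter) in this assay. Among these compounds, this is the first single-place comparison, and it shows that the group at this position affects the dose needed, with this change lowering it. No measurement available explains the step.

Going by these compounds, the new group differs from the old one in more than one part, so the part responsible remains open. On these data alone, whether a carboxylic acid or a longer chain in this place would lower the number further also remains open.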